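Replacing one aryl group on the saturated ring carbon

A few compounds are considered here, and "the series" means these few. Any claim that something is new, unique, unknown or untested is made for them only; others in the source may bear on it.

Of the compounds shown here, three that share a core have been measured in a functional assay; on this read-out lower numbers stand for stronger inhibition and higher numbers for weaker inhibition. Compound 1 `N#CC1=C(N)OC(c2c[nH]c3ccccc23)=C(C#N)C1c1ccccc1Cl` carries a 2-chlorophenyl on the saturated ring carbon; in this assay compound 1 reaches only the limit > 1000 ug/mL, which is not a number but the edge of the assay, as noted in the limit of > 1000 ug/mL in this assay, at which 1 of the 3 values shown sits. Compound 2 `CN(C)c1ccc(C2C(C#N)=C(N)OC(c3c[nH]c4ccccc34)=C2C#N)cc1` carries a 4-(dimethylamino)phenyl there instead, and in this assay compound 2 gives 900 ug/mL. Compound 3 `COc1cc(Br)c(C2C(C#N)=C(N)OC(c3c[nH]c4ccccc34)=C2C#N)cc1OC` gives 880 ug/mL in this assay. Going by the values given here, compound 2 and compound 3 thus give numbers within the scatter of each other, and the only step measured at the saturated ring carbon, an at least 1.1-fold lower number from compound 1 to compound 2 (0.04 log units; that floor lies within the scatter), starts from a limit and is itself within the scatter.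

Compound 4 `Cc1ccccc1C1C(C#N)=C(N)OC(c2c[nH]c3ccccc23)=C1C#N` differs from compound 2 by 2-methylphenyl in place of 4-(dimethylamino)phenyl on a saturated ring carbon. Among the compounds with values here, the one measured step touching that position gives no sign of a change beyond the scatter, so no clear movement in this assay is expected. The number expected for compound 4 is 950 ug/mL, with a range from 550 ug/mL to 1700 ug/mL. The expected step of a 1.1-fold higher number from compound 2 to compound 4 (0.02 log units; within the scatter) is therefore estimated to lie within the scatter, and a limit like that of compound 1 remains possible.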

Compound 4, half-maximal inhibitory concentration: > 1000 ug/mL
Compound 4: only a limit was reported; the forecaster's own chance of this, stated with the estimate: 45%; middle value at least 1.0-fold (0.02 log units) away from the limit.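

Putting 2-methylphenyl in place of 4-(dimethylamino)phenyl on the saturated ring carbon gives an at least 1.1-fold higher number from compound 2 to compound 4 (0.04 log units; that floor lies within the scatter), so a second change at this position also shows no movement beyond the scatter. In this assay compound 4 gives > 1000 ug/mL, which is a limit of the assay and not a number, so the step has only a floor and its true size could be small or larger. Compound 1, with 2-chlorophenyl, and compound 4, with 2-methylphenyl, now both stand at that limit, the step between them cannot be read, and the edge of the assay has become a main feature of this small set: the limit of > 1000 ug/mL in this assay, at which 2 of the 4 values shown sit.

The compounds shown leave open whether any group on the saturated ring carbon can bring the number clearly down, since no step at this position is yet printed as beyond the scatter. Going by these compounds alone, a phenyl bearing a carboxylic acid, or one bearing an amine on a longer chain, would test this with groups unlike those at this position so far.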